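Compound 4: trifluoromethoxy in place of trifluoromethyl

The source may report more compounds than this note shows. Statements on the series, on what has been measured and on what is new or still open speak of the compounds shown alone.

In an ADME assay on HepG2 cells (Homo sapiens) for cytotoxicity, with a stated time of 72 h (a higher number here means that more compound is needed for the effect, a lower number that less compound is needed), compound 1 `CSc1ccc(NC(=O)Nc2cc(C)nc3ccccc23)cc1` gives 16000 nM as its value. Compound 2 `Cc1ccc(NC(=O)Nc2cc(C)nc3ccccc23)cc1` gives > 25000 nM as a limit of the assay, not a number. Compound 3 `Cc1cc(NC(=O)Nc2ccc(C(F)(F)F)cc2)c2ccccc2n1` gives 23000 nM and stands level with compound 1 within the scatter.

Compound 4 `Cc1cc(NC(=O)Nc2ccc(OC(F)(F)F)cc2)c2ccccc2n1` carries trifluoromethoxy in place of trifluoromethyl on an aromatic carbon, para to a large group. Going by the values given here, three measured steps bear on this change. Trifluoromethyl in place of methylsulfanyl gives a small step (a 1.4-fold higher number from compound 1 to compound 3 (0.16 log units; within the scatter)). Methyl in place of methylsulfanyl (an at least 1.5-fold higher number from compound 1 to compound 2 (0.19 log units; that floor lies within the scatter)) and trifluoromethyl in place of methyl (an at least 1.0-fold lower number from compound 2 to compound 3 (0.03 log units; that floor lies within the scatter)) rest on the limit and give only floors. None of the three leaves the scatter, so no step beyond the scatter is expected here, and no direction is favoured.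

The expected step (a 1.0-fold lower number from compound 3 to compound 4 (0.02 log units; within the scatter)) is estimated to stay within the scatter. For compound 4 the expected value is 22000 nM with an estimated range from 12000 nM to 35000 nM in this series.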

Compound 4, half-maximal effective concentration: 15000 nM
The estimate for compound 4 lay 1.5-fold (0.17 log units) above the measured number; the measured number falls inside the stated range.
By their numbers in this assay, from the lowest: compounds 4, 1 and 3 (each within the scatter of the next). At a limit, above all of these: compound 2.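

In this assay, trifluoromethoxy at this position, para to a large group, gives a small step from trifluoromethyl (a 1.5-fold lower number from compound 3 to compound 4 (0.19 log units; within the scatter)) and from methylsulfanyl (a 1.1-fold lower number from compound 1 to compound 4 (0.03 log units; within the scatter)), so bringing in a hydrogen-bond acceptor here leaves the number within the scatter of both. Compound 2 stands at a limit of the assay, > 25000 nM, and this is not a number. Against methyl only a floor can be read (an at least 1.6-fold lower number from compound 2 to compound 4 (0.22 log units; that floor lies within the scatter)), so no step at this position has yet left the scatter, and the top of the readable range lies close to these values: the limit of > 25000 nM in this assay, at which 1 of the 4 values shown sits.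

On these data alone, it stays open whether an amine or a carboxylic acid at this position would move the number beyond the scatter. As far as these compounds go, the true size of the step between methyl and trifluoromethoxy also stays open.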